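Changing the amine on compound 3

A few compounds are considered here, and "the series" means these few. Any claim that something is new, unique, unknown or untested is made for them only; others in the source may bear on it.

In a functional assay on SK-BR-3 cells (Homo sapiens) for antiproliferative activity (on this read-out higher numbers stand for weaker inhibition and lower numbers for stronger inhibition), compound 1 `CC(=O)Oc1ccc(C(=O)Nc2cc3ccc(OCC4CCN(C)C4)c(C)c3oc2=O)cc1CC=C(C)C` gives 880 nM and compound 2 `CC(C)=CCc1cc(C(=O)Nc2cc3ccc(OCC4CCCN(C)C4)c(C)c3oc2=O)ccc1O` gives 1300 nM on the same scale. Compound 3 `CCN(CC)CCCOc1ccc2cc(NC(=O)c3ccc(O)c(CC=C(C)C)c3)c(=O)oc2c1C` gives 4900 nM as the highest number of the three. Compound 4 `CC(C)=CCc1cc(C(=O)Nc2cc3ccc(OCCCN(C)C(C)(C)C)c(C)c3oc2=O)ccc1O` differs from compound 3 by one swap at the end of the chain, methyl(tert-butyl)amino in place of diethylamino on a saturated chain carbon, three bonds along the chain from an oxygen on an aromatic ring in all. Among the compounds with values here, the one measured step that bears on this is a 3.8-fold higher number from compound 2 to compound 3 (0.58 log units; beyond the scatter) and it was modest, with 2-(diethylamino)ethyl replacing a ring group. Here neither amine has a ring, so no step beyond the scatter is expected in this assay for this swap. The estimated step is a 1.2-fold lower number from compound 3 to compound 4 (0.09 log units; within the scatter) and no more. For compound 4 the expected value is 4000 nM with an estimated span of 1600 nM to 10000 nM as its range.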

Compound 4, half-maximal inhibitory concentration: 880 nM
For compound 4 the middle estimate is 4.5-fold (0.66 log units) above the measured one; the whole stated range lies above it.
By their numbers in this assay, from the lowest: compounds 1, 4 and 2 (each within the scatter of the next); then compound 3.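

In this assay, the amine at the end of this chain matters even when no ring is involved: methyl(tert-butyl)amino in place of diethylamino gives (a 5.6-fold lower number from compound 3 to compound 4 (0.75 log units; beyond the scatter)). Against the ring amine of compound 2, the reading is (a 1.5-fold lower number from compound 2 to compound 4 (0.17 log units; within the scatter)), so an amine without a ring can match it here, though the diethylamino of compound 3 does not. Nothing available explains why this swap counts. Still open, from the compounds shown here alone, is how dimethylamino or methyl(isopropyl)amino would read on the same chain, and so whether the tert-butyl group itself is what matters.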